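This account rests on a few compounds, and the source may have more. Where it says the series, first, only, none or still open, it means among the compounds named here.

Compound 1 `O=C(CCCCCCN1C(=O)/C(=N\O)c2cc(Br)ccc21)NO` and compound 2 `Cc1ccc2c(c1)/C(=N/O)C(=O)N2CCCCCCC(=O)NO` share one core; compound 3 `CO/N=C1/C(=O)N(CCCCCCC(=O)NO)c2ccc(Br)cc21` and compound 4 `CO/N=C1/C(=O)N(CCCCCCC(=O)NO)c2ccc(C)cc21` share another, and the difference between the two cores is not broken down here. In a functional assay on PC-3 cells (Homo sapiens) for antiproliferative activity, read by sulforhodamine B assay, with a stated time of 48 h (a lower number here means a stronger inhibitor, a higher number a weaker inhibitor), compound 1 gives 2210 nM, compound 2 gives 620 nM, and compound 3 gives 8910 nM; compound 3 thus stands highest of the three measured, with compound 1 nearest and compound 2 furthest. The change from compound 1 to compound 2 is methyl in place of bromo on an aromatic carbon and brings a 3.6-fold lower number from compound 1 to compound 2 (0.55 log units; beyond the scatter), a modest step. The change from compound 3 to compound 4 is methyl in place of bromo on an aromatic carbon; it is the same change, placed on the second core, and it occurs twice among the compounds shown. Compound 4 has not yet been measured in this assay. For the measured compounds named here, for compound 4 the step of a 3.2-fold lower number from compound 3 to compound 4 (0.50 log units; beyond the scatter) is expected, set beside the earlier one, because the measured step of a 3.6-fold lower number from compound 1 to compound 2 (0.55 log units; beyond the scatter) is the only guide to this change and the core of compound 3 differs, so the range is kept wide. The expected value for compound 4 is 2800 nM, between 1000 nM and 7500 nM.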

Compound 4, half-maximal inhibitory concentration: 350 nM
Compound 4: the middle estimate sits 8.0-fold (0.90 log units) above what was measured; measured number outside the range, below it.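

In this assay the new step, a 25-fold lower number from compound 3 to compound 4 (1.41 log units; beyond the scatter), is large and runs in the same direction as the step on the core of compound 1. Methyl in place of bromo on an aromatic carbon therefore lowers the number on both cores, but the size of the step does not carry over from one core to the other: the same change on two cores in this assay, a 3.6-fold lower number (0.55 log units; beyond the scatter) from compound 1 to compound 2 and a 25-fold lower number (1.41 log units; beyond the scatter) from compound 3 to compound 4, 7.1-fold (0.85 log units) apart, beyond the scatter of two such steps These two pairs show that a step measured on one core gave the direction but not the size on the other; they do not show which difference between the cores goes with the larger step, and they give no rule for any further core.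

Going by these compounds, it remains open whether the two cores also part this widely with other groups on the same aromatic carbon, such as chloro, methoxy or trifluoromethyl. On these data alone, it is equally open whether the gap between the two steps persists with a longer chain in place of the present one.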